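Carbonate side chain: hydroxy terminus replaced by aminomethyl

The source may report more compounds than this note shows. Statements on the series, on what has been measured and on what is new or still open speak of the compounds shown alone.

Of the compounds shown here, three on a shared core have been measured in a physicochemical assay for lipophilicity; a higher number here means a more lipophilic compound, a lower number a more polar compound. Compound 1 `Cc1cn(C2CC(N=[N+]=[N-])C(COC(=O)CCCN)O2)c(=O)[nH]c1=O` gives -0.9. Compound 2 `Cc1cn(C2CC(N=[N+]=[N-])C(COC(=O)OCCO)O2)c(=O)[nH]c1=O` gives -1.2 and stands lowest of the three numbers, though its step to compound 1 is within the scatter. Compound 3 `Cc1cn(C2CC(N=[N+]=[N-])C(COC(=O)OCCCCCO)O2)c(=O)[nH]c1=O` gives -0.45, the highest of the three, with a number 0.75 log units higher from compound 2 to compound 3 (beyond the scatter) and a number 0.45 log units higher from compound 1 to compound 3 (beyond the scatter) both beyond the scatter.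

Compound 4 `Cc1cn(C2CC(N=[N+]=[N-])C(COC(=O)OCCCN)O2)c(=O)[nH]c1=O` is not yet measured. Its difference from compound 2 is aminomethyl in place of hydroxy on a saturated chain carbon, two bonds along the chain from an oxygen next to a carbonyl group.

Among the compounds with values here, two measured steps bear on this. The change of terminus from an amine-bearing chain to a hydroxy-bearing one is covered by a number 0.30 log units lower from compound 1 to compound 2 (within the scatter), a small step within the scatter. Chain lengthening is covered by a number 0.75 log units higher from compound 2 to compound 3 (beyond the scatter), a modest rise for three added chain carbons. Compound 4 adds one carbon and swaps hydroxy for an amine, so a small rise from compound 2 is expected, likely within the scatter, as the step of a number 0.25 log units higher from compound 2 to compound 4 (within the scatter). For compound 4 the expected value in this assay is therefore -0.95, with a range of -1.5 to -0.4.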

Compound 4, partition coefficient: -0.93
The estimate for compound 4 lay 0.02 log units below the measured number; measured number inside the range.
By their numbers in this assay, from the lowest: compounds 2, 4 and 1 (each within the scatter of the next); then compound 3.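

In this assay, putting aminomethyl in place of hydroxy on a saturated chain carbon, two bonds along the chain from an oxygen next to a carbonyl group, gives a step that cannot be told from the scatter (a number 0.27 log units higher from compound 2 to compound 4 (within the scatter)). The change from 3-aminopropyl to 3-aminopropoxy on a carbonyl carbon is just as unresolved (a number 0.03 log units lower from compound 1 to compound 4 (within the scatter)), so this assay separates neither that change nor the change of terminus at this chain length. Within the data shown here, only the step with amino in place of 2-hydroxyethyl, three bonds along the chain from an oxygen next to a carbonyl group, is beyond the scatter (a number 0.48 log units lower from compound 3 to compound 4 (beyond the scatter)), and it changes chain length and terminus together, leaving compound 3 apart from compounds 1, 2 and 4.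

No measured evidence explains these numbers. Still open, from the compounds shown here alone, is whether a 5-aminopentoxy chain would stand with compound 3 or with compound 4, which would separate chain length from terminus, and how a carboxylic acid at the chain end would compare with the hydroxy and amine termini.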